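The source may hold more compounds than are shown below. What is called first, only, known or untested is meant among the compounds shown, and "the series" means these compounds.

Compound 1 `O=C(Nc1ccccc1)C(Cl)Cl` was taken into a functional assay on KB cells (Homo sapiens) for antiproliferative activity, read by MTT assay, with a stated time of 72 h (a lower number here means a stronger inhibitor, a higher number a weaker inhibitor), and for compound 1 the entry there reads "not determined" (no result reported). Compound 2 `O=C(Nc1ccccc1F)C(Cl)Cl` was taken into this assay as well, and for compound 2 the entry reads "not determined" (no result reported). Among the measured compounds shown here, compound 3 `O=C(Nc1ccccc1Br)C(Cl)Cl` is the one entry with a figure: in this assay compound 3 gives 67900 nM, and it therefore stands alone as the only numbered point of the series, with no step between measured compounds available to lean on. On its own terms it is a weak inhibitor.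

The next entry is compound 4 `O=C(Nc1ccccc1[N+](=O)[O-])C(Cl)Cl`, which carries a nitro group where compound 3 carries a bromo. The change from compound 3 to compound 4 is nitro in place of bromo on an aromatic carbon. Nothing in the measured set shows what this exchange does in this assay; compounds 1 and 2 report no number, so the direction of any step is open.

With a single anchor, the expectation for compound 4 is kept close to compound 3: a step from compound 3 to compound 4 of a 1.1-fold lower number from compound 3 to compound 4 (0.05 log units; within the scatter) is expected, no larger than the usual scatter in either direction. For compound 4 the estimated result in this assay is 60000 nM, with a range from 20000 nM to 200000 nM.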

Compound 4, half-maximal inhibitory concentration: 253000 nM
For compound 4 the middle estimate is 4.2-fold (0.62 log units) below the measured one, and the stated range ends below it.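

In this assay, nitro in place of bromo on this aromatic carbon, ortho to a group of 6 heavy atoms, gives a 3.7-fold higher number from compound 3 to compound 4 (0.57 log units; beyond the scatter), so the position is not indifferent to what it carries. Among the compounds shown here, this is the first readable step, and it shows that, of this pair, compound 3 is the stronger inhibitor, with a gap beyond the usual scatter but modest in size, so one exchange on the shared core moves the result only so far. No measurement shown accounts for the direction or size of this step.

Going by these compounds, compound 1 and compound 2 report no number, so steps to them cannot be read, and it stays open whether bromo itself favours activity or nitro disfavours it relative to the unsubstituted ring or to fluoro. Also open, on these data alone, is how an amine, a methoxy group or a carboxylic acid at this same place would compare with compound 3, and whether the same exchange would give a step of similar direction at another ring carbon.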